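A few compounds are considered here, and "the series" means these few. Any claim that something is new, unique, unknown or untested is made for them only; others in the source may bear on it.

In an assay on cells for inhibition of cytochrome P450 11B2, mitochondrial (Homo sapiens), read by HTRF (a higher number here means a weaker inhibitor, a lower number a stronger inhibitor), compound 2, `CC(=O)N[C@H]1CCCc2c1cncc2N1Cc2cc(Cl)ccc2C1=O`, gives 5140 nM. Within the data shown here, that is the higher of the two numbers measured so far; the only other compound, compound 1, `CC(=O)N[C@@H]1CCCc2c1cncc2N1C(=O)c2ccc(Cl)cc2[C@@H]1C1CC1`, gives 354 nM in this assay, a lower number by a gap beyond the usual scatter of repeated measurements. Among the measured compounds shown here, no direct step between these two compounds has been worked out, since they differ in more than one place, so their values can only be set side by side.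

Compound 3, `CC(=O)N[C@@H]1CCCc2c1cncc2N1Cc2cc(Cl)ccc2C1=O`, has not yet been measured in this assay. It differs from compound 2 only in configuration: the two compounds have the same atoms and bonds and differ only in configuration as drawn: 1 of 1 stereo elements differ; a stereocentre at a saturated ring carbon is drawn S in compound 2 and R in compound 3. In other words, compound 3 is the mirror form of compound 2 at its single stereocentre. For the measured compounds named here, nothing measured so far tells how this assay responds to that inversion, so the direction rests on experience that one mirror form usually binds clearly better than the other. Because compound 2 already gives 5140 nM, the weaker of the two numbers seen, the inversion is expected to move compound 3 toward a lower number, a step of an 8.6-fold lower number from compound 2 to compound 3 (0.93 log units; beyond the scatter) that should exceed the scatter. The estimate for compound 3 in this assay is 600 nM, within a range from 120 nM to 3000 nM.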

Compound 3, half-maximal inhibitory concentration: 44 nM
Compound 3: middle estimate off by 14-fold (1.13 log units), on the high side; measured number below the stated range.
By their numbers in this assay, from the lowest: compound 3; then compound 1; then compound 2.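

In this assay, the single stereocentre at a saturated ring carbon turns out to matter a great deal: changing it from S as drawn to R gives a 120-fold lower number from compound 2 to compound 3 (2.07 log units; beyond the scatter), a large step that the earlier pair, differing in more than one place, could not reveal. Among these compounds, this step can be credited to the stereocentre alone, because nothing else separates the two structures: the fact that compounds 2 and 3 differ only in the configuration as drawn The result also opens the first one-place comparison with the cyclopropyl compound, where hydrogen in place of cyclopropyl on a saturated ring carbon gives an 8.0-fold lower number from compound 1 to compound 3 (0.91 log units; beyond the scatter), a modest step but beyond the scatter, so the lowest number of the three is reached without the cyclopropyl group.

Among the compounds shown here, only one pair of mirror forms stands here, so it remains open whether an inversion would weigh as heavily in a compound that carries cyclopropyl, as compound 1 does. Also open, going by these compounds, is how a group of intermediate size, such as a methyl group in place of the cyclopropyl, would read in this assay, and whether a nitrile in place of the chlorine would keep the low number of compound 3.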